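Replacing the amide substituent of compound 1

The source may report more compounds than this note shows. Statements on the series, on what has been measured and on what is new or still open speak of the compounds shown alone.

Values in a functional assay on HeLa cells (Homo sapiens) for cytotoxicity, read by MTT assay, with a stated time of 48 h; a lower number here means a stronger inhibitor, a higher number a weaker inhibitor:
Compound 1 `COc1cc([C@@H]2C[C@]2(CO)C(=O)Nc2ccccc2Cl)cc(OC)c1OC`: 8100 nM
Compound 2 `CCOC(=O)C1(C(=O)NCc2ccc(F)cc2)CC1c1cc(OC)c(OC)c(OC)c1`: 32300 nM; 27800 nM (2 entries)
Compound 3 `CCOC(=O)C1(C(=O)Nc2ccccc2)CC1c1cc(OC)c(OC)c(OC)c1`: > 100000 nM; > 100000 nM (2 entries)

In this assay, going by the values given here, compound 1 is the only compound with a single number, 8100 nM. Compound 2 has two entries, (the several entries of compound 2 in this assay, 32300 nM; 27800 nM (2 entries)). For compound 3 the reading > 100000 nM; > 100000 nM (2 entries) is a limit of the assay and not a number.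

Compound 4 `COc1cc([C@@H]2C[C@]2(CO)C(=O)NCc2ccc(C)cc2)cc(OC)c1OC` keeps the core of compound 1 and differs at one place: 4-methylbenzyl in place of 2-chlorophenyl on an amide-type nitrogen. Among the compounds with values here, no measured pair isolates this change, so its size can only be judged loosely. A moderate move towards weaker inhibition is expected in this assay, since compound 2 with its benzyl-type amide gives 32300 nM; 27800 nM (2 entries). The estimated change is a 2.5-fold higher number from compound 1 to compound 4 (0.39 log units; beyond the scatter). Compound 4 is estimated at 20000 nM, with an expected range from 7000 nM to 55000 nM.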

Compound 4, half-maximal inhibitory concentration: 17400 nM
Compound 4: middle estimate off by 1.1-fold (0.06 log units), on the high side; the range from low to high includes it.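

In this assay, going by these compounds alone, 4-methylbenzyl in place of 2-chlorophenyl on the amide-type nitrogen gives a 2.1-fold higher number from compound 1 to compound 4 (0.33 log units; beyond the scatter), the only measured step at this position, and it is a modest one. The change swaps the chlorine for a methyl group and also adds a carbon between the nitrogen and the ring, and this single step cannot separate the two. Compound 2 also has a benzyl-type amide but differs from compound 4 in more than one place, so it offers no clean comparison: the several entries of compound 2 in this assay, 32300 nM; 27800 nM (2 entries)

The compounds shown leave open how 2-chlorobenzyl or 4-methylphenyl would read on this nitrogen, either of which would help to separate those two parts of the change. They also leave open what an amine or a carboxylic acid on the aromatic ring would do.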